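Adding a methyl to compound 3

This account rests on a few compounds, and the source may have more. Where it says the series, first, only, none or still open, it means among the compounds named here.

Three compounds sharing one core differ only in the aryl group on a saturated ring carbon. In a functional assay (on this read-out higher numbers stand for weaker inhibition and lower numbers for stronger inhibition), compound 1 (`CC(C)=CCOc1cc(O)c2c(c1)OC(c1ccccc1F)CC2=O`) gives 5300 nM and compound 2 (`CC(C)=CCOc1cc(O)c2c(c1)OC(c1cccc(F)c1)CC2=O`) gives 7240 nM while compound 3 (`CC(C)=CCOc1cc(O)c2c(c1)OC(c1ccc(C)cc1)CC2=O`) gives 4360 nM on the same read-out. Compound 3 cannot be separated from the other two: the data show a 1.2-fold lower number from compound 1 to compound 3 (0.08 log units; within the scatter) and a 1.7-fold lower number from compound 2 to compound 3 (0.22 log units; within the scatter) as its two steps, each within the scatter. Compound 4 (`CC(C)=CCOc1cc(O)c2c(c1)OC(c1ccc(C)cc1C)CC2=O`) carries methyl in place of hydrogen on an aromatic carbon, ortho to a large group and meta to a methyl group, so 4-methylphenyl becomes 2,4-dimethylphenyl. Among the measured compounds shown here, no measured step adds a group to compound 3, so the aryl swaps are the nearest guide, and a 1.4-fold higher number from compound 1 to compound 2 (0.14 log units; within the scatter) also stays within the scatter. The expected change is a 1.1-fold lower number from compound 3 to compound 4 (0.04 log units; within the scatter) in this assay and no step beyond the scatter is anticipated. Compound 4 is estimated at 4000 nM with an expected range (2000 nM to 8000 nM).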

Compound 4, half-maximal inhibitory concentration: 6380 nM
Estimate against measurement, compound 4: 1.6-fold (0.20 log units) below; the range from low to high includes it.
By their numbers in this assay, from the lowest: compounds 3, 1, 4 and 2 (each within the scatter of the next).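

In this assay, methyl in place of hydrogen on an aromatic carbon, ortho to a large group, gives a 1.5-fold higher number from compound 3 to compound 4 (0.17 log units; within the scatter), so this position accepts a second ring substituent without a step that can be told from the scatter. The 2,4-dimethylphenyl compound also cannot be separated from either fluorophenyl compound, with a 1.2-fold higher number from compound 1 to compound 4 (0.08 log units; within the scatter) and a 1.1-fold lower number from compound 2 to compound 4 (0.05 log units; within the scatter). All the aryl groups shown, now including a disubstituted one, therefore remain unresolved on this read-out, and nothing available explains these small steps.

The aryl rings shown carry only fluorine or methyl, so it remains open whether an amine, a carboxylic acid or a longer chain at this place would produce a step beyond the scatter.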